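Dimethylphenyl Amides of a Piperidine Series

A few compounds are considered here, and "the series" means these few. Any claim that something is new, unique, unknown or untested is made for them only; others in the source may bear on it.

Measured compounds in a functional assay on HEK293 cells for agonist activity at D(4) dopamine receptor (Homo sapiens), read by FLIPR; a higher number here means a larger maximal response, a lower number a smaller maximal response:
compound 1 `Cc1cc(C)cc(NC(=O)CN2CCC(c3cccc[n+]3[O-])CC2)c1` gives 76%
compound 2 `O=C(NCN1CCC(c2cccc[n+]2[O-])CC1)c1ccc(F)c(Cl)c1` gives 67%
compound 3 `Cc1cccc(C(=O)NCN2CCC(c3cccc[n+]3[O-])CC2)c1` gives 77%

Compound 1 stands second highest of the three numbers. Its nearest neighbour is compound 3, and the gap between them lies within the scatter, as does its gap to compound 2. Among the measured compounds shown here, the only measured step, a number 10 percentage points higher from compound 2 to compound 3 (within the scatter), exchanges the aryl group on the carbonyl carbon and stays within the scatter.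

The unmeasured compound 4 `Cc1cccc(C)c1NC(=O)CN1CCC(c2cccc[n+]2[O-])CC1` differs from compound 1 on the other side of the amide: 2,6-dimethylphenyl in place of 3,5-dimethylphenyl on an amide-type nitrogen. For the measured compounds named here, no measured step touches the aryl group on the amide-type nitrogen, so nothing in this assay speaks directly to the change. Going by the values given here, the three measured numbers sit close together, and the one step that exchanges an aryl group stays within the scatter. It is therefore expected that the step of a number 4 percentage points lower from compound 1 to compound 4 (within the scatter) also stays within the scatter. Compound 4 is estimated at 72%, within 52% to 90%.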

Compound 4, largest response reached (reported as efficacy), in percent of the reference or control that the assay uses: 68%
The estimate for compound 4 lay 4 percentage points above the measured number, within the range that was stated.
By their numbers in this assay, from the lowest: compounds 2, 4, 1 and 3 (each within the scatter of the next).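

Among the compounds shown here, exchanging 3,5-dimethylphenyl for 2,6-dimethylphenyl on the amide-type nitrogen gives in this assay the step of a number 8 percentage points lower from compound 1 to compound 4 (within the scatter) and is the only measured change at this place. The two compounds have the same atoms joined differently, and on this single pair the maximal response does not separate the two dimethylphenyl groups. Like the step of a number 10 percentage points higher from compound 2 to compound 3 (within the scatter) on the carbonyl carbon, this exchange of aryl groups stays within the scatter, and no evidence is at hand that bears on this result.

The compounds shown leave open whether a plain phenyl, a cyclohexyl or a pyridyl group on this amide-type nitrogen would give a response beyond the scatter of compound 1. They also leave open what a single methyl group or a methoxy group on the phenyl ring would do here.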